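Triazolothiadiazinone series: butylamino to 2-fluorophenyl at the thiadiazole carbon

The source may report more compounds than this note shows. Statements on the series, on what has been measured and on what is new or still open speak of the compounds shown alone.

Measured so far in an ADME assay on cells for inhibition of Intestinal-type alkaline phosphatase (Homo sapiens), read by luminescence, with stated times of 7 min and 20 min; on this read-out higher numbers stand for weaker inhibition and lower numbers for stronger inhibition:
- compound 1 `CCCCNc1nn2c(=O)cc(C(F)(F)F)nc2s1` gives 710 nM
- compound 2 `Cc1cc(C)cc(-c2nn3c(=O)cc(C(F)(F)F)nc3s2)c1` gives 460 nM
- compound 3 `COc1cc(OC)cc(-c2nn3c(=O)cc(C(F)(F)F)nc3s2)c1` gives 760 nM

Compound 1 holds the second highest of the three numbers. Its nearest neighbour is compound 3, whose number is within the scatter of that of compound 1; compound 2 shows a lower number, but that gap also lies within the scatter. On these three values no ordering of the butylamino and the two aryl substituents at the thiadiazole carbon can be claimed.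

Compound 4 `O=c1cc(C(F)(F)F)nc2sc(-c3ccccc3F)nn12` carries a 2-fluorophenyl where compound 1 carries the butylamino: 2-fluorophenyl in place of butylamino on an aromatic carbon. Among the compounds with values here, no pair of measured compounds differs in this single place, so no measured step is available for it. Within the data shown here, the two aryl analogues, compound 2 and compound 3, sit within the scatter of compound 1, which is the only guide here. The expected step from compound 1 to compound 4 in this assay is therefore small, a 1.3-fold lower number from compound 1 to compound 4 (0.11 log units; within the scatter), not clearly beyond the scatter in either direction. For compound 4 the estimate is 550 nM, with a range from 200 nM to 1500 nM.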

Compound 4, half-maximal inhibitory concentration: > 100000 nM
Compound 4: a limit, no number (the forecaster's own chance of this, stated with the estimate: 5%); at least 180-fold (2.25 log units) between middle value and limit.
By their numbers in this assay, from the lowest: compounds 2, 1 and 3 (each within the scatter of the next). At a limit, above all of these: compound 4.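

In this assay, within the data shown here, this aromatic carbon proves far less tolerant than the earlier compounds indicated: 2-fluorophenyl in place of butylamino gives an at least 140-fold higher number from compound 1 to compound 4 (2.14 log units; beyond the scatter), a step that rests on a limit. Compound 4 stands at a limit of the assay, not at a number: the limit of > 100000 nM in this assay, at which 1 of the 4 values shown sits. An aryl group at this carbon does not by itself bring this loss, since compound 2 gives 460 nM and compound 3 gives 760 nM, so the outcome depends on which aryl group is present.

Still open, from the compounds shown here alone, is whether the fluorine or the substitution pattern on the phenyl ring accounts for the loss, a question that unsubstituted phenyl or 4-fluorophenyl would address. Also open, going by these compounds, is how a longer alkylamine or a cyclic amine would fare at this carbon compared with butylamino.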